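This account rests on a few compounds, and the source may have more. Where it says the series, first, only, none or still open, it means among the compounds named here.

Compound 2 `O=C(CCCCC1CCSS1)NCc1cn(CCCCCOc2ccc3ccc(=O)oc3c2)nn1` was tested in a functional assay on PC-12 cells (Rattus norvegicus) for cytotoxicity, read by MTT assay, with stated times of 3 h and 2 h, tested at 5 uM (a lower number here means a weaker effect, a higher number a stronger effect of the compound at the concentration tested), and gave 64.5%. Compound 1 `O=C(CCCCC1CCSS1)NCc1cn(CCCOc2ccc3cc(C(=O)O)c(=O)oc3c2)nn1` gave 57% in this assay, and compound 3 `Cc1cc(=O)oc2cc(OCCCCCn3cc(CNC(=O)CCCCC4CCSS4)nn3)ccc12` gave 61%; both of these numbers lie within the usual scatter of the number for compound 2. Among the measured compounds shown here, the only measured change on the shared core is a number 3.5 percentage points lower from compound 2 to compound 3 (within the scatter), a small group added on an aromatic carbon, a step inside the scatter. Compound 4 `O=C(CCCCC1CCSS1)NCc1cn(CCCCCOc2ccc3cc(-c4ccc(Br)cc4)c(=O)oc3c2)nn1` differs from compound 2 by 4-bromophenyl in place of hydrogen on an aromatic carbon. For the measured compounds named here, no measured step introduces a group of this size, so the one small step gives only weak guidance. In this assay compound 4 is therefore expected to give 64%, between 50% and 78%. The expected step of a number 0.5 percentage points lower from compound 2 to compound 4 (within the scatter) is estimated as none beyond the scatter.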

Compound 4, a percentage reported as activity, at one concentration (the size of the read-out at that concentration, not a potency): 45.7%
For compound 4 the middle estimate is 18.3 percentage points above the measured one; measured number outside the range, below it.
By their numbers in this assay, from the lowest: compound 4; then compounds 1, 3 and 2 (each within the scatter of the next).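

In this assay, the aromatic carbon two atoms from the ring oxygen does not tolerate every change: 4-bromophenyl in place of hydrogen gives a number 18.8 percentage points lower from compound 2 to compound 4 (beyond the scatter). The only earlier step on the shared core, a number 3.5 percentage points lower from compound 2 to compound 3 (within the scatter), stayed inside the scatter, so this is the first single change shown to move the read-out. Nothing available bears on why the number falls. Going by these compounds, it remains open whether the bromine or the phenyl ring carries this step, which a plain phenyl at this carbon would separate. On these data alone, whether a small group here, such as fluorine or an amine, would also lower the number is equally open.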